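A few compounds are considered here, and "the series" means these few. Any claim that something is new, unique, unknown or untested is made for them only; others in the source may bear on it.

Going by the values given here, compound 2 `Cn1c(=O)c(S(=O)(=O)c2ccc(F)cc2F)cc2cnc(Nc3cccc4[nH]ccc34)nc21` gives 1500 nM in a functional assay on K562 cells (Homo sapiens) for inhibition, read by trypan blue exclusion, with a stated time of 72 h (a higher number here means a weaker inhibitor, a lower number a stronger inhibitor), the lower of the two numbers so far; compound 1 `Cn1c(=O)c(S(=O)(=O)c2ccc(F)cc2F)cc2cnc(Nc3ccc4[nH]c(C(=O)O)cc4c3)nc21` gives 10000 nM in this assay. Among the compounds with values here, the only measured step, a 6.7-fold lower number from compound 1 to compound 2 (0.82 log units; beyond the scatter), alters both the carboxy group and the point of attachment at once, so it bears only loosely on compound 3 `Cn1c(=O)c(S(=O)(=O)c2ccc(F)cc2F)cc2cnc(Nc3ccc4sccc4c3)nc21`, which carries 1-benzothiophen-5-yl in place of 1H-indol-4-yl on a nitrogen on an aromatic ring. Within the data shown here, no measured pair isolates this change, so the expected step of a 1.7-fold higher number from compound 2 to compound 3 (0.22 log units; within the scatter) is modest, with some lean toward a weaker inhibitor. Compound 3 is estimated at 2500 nM, between 800 nM and 8000 nM.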

Compound 3, half-maximal inhibitory concentration: 500 nM
The estimate for compound 3 lay 5.0-fold (0.70 log units) above the measured number, outside the stated range (below it).
By their numbers in this assay, from the lowest: compound 3; then compound 2; then compound 1.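

On the nitrogen on an aromatic ring, 1-benzothiophen-5-yl in place of 1H-indol-4-yl gives a 3.0-fold lower number from compound 2 to compound 3 (0.48 log units; beyond the scatter) in this assay, so the group that enters, with no hydrogen-bond donor, is not worse here than the one that leaves. Against the 2-carboxy-1H-indol-5-yl group, the change gives a 20-fold lower number from compound 1 to compound 3 (1.30 log units; beyond the scatter), which puts compound 3 lowest of the three. No supporting data explain these steps. Open, from the compounds shown here alone, is whether the sulfur or the changed point of attachment carries the step from compound 2, and whether an amine on the 1-benzothiophen-5-yl group keeps the number as low.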